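Shrinking a Ring on the Sulfonyl of Compound 2

A few compounds are considered here, and "the series" means these few. Any claim that something is new, unique, unknown or untested is made for them only; others in the source may bear on it.

Measured so far:
- compound 1, `CCN(CC)S(=O)(=O)c1ccc(S(=O)(=O)N2CCC[C@@H](C(=O)N3CCC(O)CC3)C2)cc1`, gives 4710 nM in a functional assay on BXPC-3 cells (Homo sapiens) for inhibition, read by MTT assay, with a stated time of 7 days; a lower number here means a stronger inhibitor, a higher number a weaker inhibitor.
- compound 2, `O=C([C@@H]1CCCN(S(=O)(=O)c2ccc(S(=O)(=O)C3CCC3)cc2)C1)N1CCC(F)(F)CC1`, gives 78 nM.
- compound 3, `CCN(CC)S(=O)(=O)c1ccc(S(=O)(=O)N2CCC[C@@H](C(=O)N3CCC(OC)CC3)C2)cc1`, gives 1420 nM.

Compound 2 stands lowest of the three numbers in this assay; compound 3 is the nearest to it and compound 1 the furthest, and both gaps lie beyond the scatter. Compound 4, `O=C([C@@H]1CCCN(S(=O)(=O)c2ccc(S(=O)(=O)C3CC3)cc2)C1)N1CCC(F)(F)CC1`, differs from compound 2 in one place: cyclopropyl in place of cyclobutyl on a sulfonyl sulfur. Going by the values given here, the only measured step, a 3.3-fold lower number from compound 1 to compound 3 (0.52 log units; beyond the scatter), concerns a different place and a different kind of change, so no measured step bears directly on this one. Among the compounds with values here, the swap exchanges one small carbon ring for another on the sulfonyl sulfur, and nothing among the measured compounds shows how such a swap moves the number. The expected step of a 1.3-fold higher number from compound 2 to compound 4 (0.11 log units; within the scatter) is therefore small, within the scatter, in no particular direction. Compound 4 is estimated at 100 nM in this assay, with a range from 40 nM to 250 nM.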

Compound 4, half-maximal inhibitory concentration: 129 nM
Beside the measured number, compound 4's estimate is 1.3-fold (0.11 log units) below it; low and high end bracket the measured number.
By their numbers in this assay, from the lowest: compounds 2 and 4 (each within the scatter of the next); then compound 3; then compound 1.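

Going by these compounds alone, this is the first measured change at this place. In this assay, putting cyclopropyl in place of cyclobutyl on the sulfonyl sulfur gives a 1.7-fold higher number from compound 2 to compound 4 (0.22 log units; within the scatter), so this assay does not separate the two rings, and the carbon lost in the swap leaves no readable mark on the number. The data give no explanation for this result, and no other measurement on these compounds bears on it.

From the compounds shown here alone, one swap between two small carbon rings says little about the wider reach of this position, so it remains open how the number would respond to a larger ring such as cyclopentyl, an open chain such as n-butyl, or an aromatic phenyl ring. It is also unknown whether the same swap would read the same way with a different group on the amide carbonyl.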